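Replacing ethoxy with dimethylamino in compound 2

This account rests on a few compounds, and the source may have more. Where it says the series, first, only, none or still open, it means among the compounds named here.

Going by the values given here, in an ADME assay on HeLa cells (Homo sapiens) for cytotoxicity, read by crystal violet staining, with a stated time of 72 h (on this read-out higher numbers stand for lower toxicity in this test and lower numbers for higher toxicity in this test), compound 2 (`CCOC(=O)c1cc(CCCOc2ccc(-c3noc(C(F)(F)F)n3)cc2-n2cccc2)on1`) gives 57300 nM, the higher of the two numbers so far, while compound 1 (`CN(C)C(=O)c1cc(CCCOc2ccc(-c3noc(C(F)(F)F)n3)cc2F)on1`) gives 20200 nM. Compound 3 (`CN(C)C(=O)c1cc(CCCOc2ccc(-c3noc(C(F)(F)F)n3)cc2-n2cccc2)on1`) has dimethylamino in place of ethoxy on a carbonyl carbon. Compound 1, at 20200 nM, also carries dimethylamino there but differs elsewhere, so it is only a loose guide. The expected change is a small fall, a 1.4-fold lower number from compound 2 to compound 3 (0.16 log units; within the scatter), no step beyond the scatter. In this assay the estimated value for compound 3 is 40000 nM, with an expected range of 17000 nM to 95000 nM.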

Compound 3, half-maximal cytotoxic concentration: 21200 nM
The estimate for compound 3 lay 1.9-fold (0.28 log units) above the measured number; the measured number falls inside the stated range.
By their numbers in this assay, from the lowest: compounds 1 and 3 (each within the scatter of the next); then compound 2.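

In this assay, going by these compounds alone, dimethylamino in place of ethoxy on a carbonyl carbon gives a 2.7-fold lower number from compound 2 to compound 3 (0.43 log units; beyond the scatter) and is the first single-place reading of this position. With dimethylamino held there, 1H-pyrrol-1-yl in place of fluoro on an aromatic carbon gives a 1.0-fold higher number from compound 1 to compound 3 (0.02 log units; within the scatter) and so leaves the number within the scatter. Nothing here bears on why the carbonyl change moves the number. Going by these compounds, whether ethoxy would stand equally high with fluoro on the aromatic carbon remains open. So does the effect of a carboxylic acid or a primary amide at the carbonyl position.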